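Flipping One Ring Stereocentre on a Hydroxamic Acid

The source may hold more compounds than are shown below. What is called first, only, known or untested is meant among the compounds shown, and "the series" means these compounds.

Compound 1 `O=C(NO)c1ccc(-c2cn([C@H]3C[C@H](C(=O)O)N(CCCc4ccccc4)C3)nn2)cc1` and compound 2 `O=C(NO)c1ccc(-c2cn([C@@H]3C[C@H](C(=O)O)N(Cc4ccccc4)C3)nn2)cc1` share the same core. In an assay on Sf9 cells for inhibition of histone deacetylase 11 (Homo sapiens), read by fluorescence, tested at 0.5 uM (on this read-out higher numbers stand for more inhibition at the one concentration tested (going by the name of the read-out) and lower numbers for less inhibition), compound 1 reads < 10%, which is a limit of the assay rather than a number. In this assay compound 2 likewise reads < 10%, again only a limit, the floor described by the limit of < 10% in this assay, at which 2 of the 2 values shown sit. Compound 3 `O=C(NO)c1ccc(-c2cn([C@H]3C[C@H](C(=O)O)N(Cc4ccccc4)C3)nn2)cc1` differs from compound 2 by the two compounds have the same atoms and bonds and differ only in configuration as drawn: 1 of 2 stereo elements differ; a stereocentre at a saturated ring carbon is drawn R in compound 2 and S in compound 3. For the measured compounds named here, no measured step exists for such a change, so no direction beyond the scatter is expected. Compound 3 is therefore expected to stay at that floor, near 5%, between 0% and 15%. This expectation amounts to a step that the limit leaves unreadable from compound 2 to compound 3, essentially none beyond the scatter.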

Compound 3, a percentage reported as inhibition, at one concentration (the size of the read-out at that concentration, not a potency): < 10%
Compound 3: only a limit was reported (the forecaster's own chance of this, stated with the estimate: 80%); the middle value is on the limit's open side.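

No step can be read among compound 1, compound 2 and compound 3, because all three sit at the same limit rather than at numbers: the limit of < 10% in this assay, at which 3 of the 3 values shown sit.

From the compounds shown here alone, whether the ring stereocentre or the chain on the amine nitrogen affects inhibition at all stays open.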